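A few compounds are considered here, and "the series" means these few. Any claim that something is new, unique, unknown or untested is made for them only; others in the source may bear on it.

Among the measured compounds shown here, compound 1 `COc1ccc(N2C(=O)COc3ccc(-c4cnc(Cl)c(NS(=O)(=O)c5ccc(F)cc5)c4)cc32)cc1` gives 30100 nM in a functional assay on HCT-116 cells (Homo sapiens) for antiproliferative activity, read by MTT assay, with a stated time of 72 h (a lower number here means a stronger inhibitor, a higher number a weaker inhibitor), and is the only member of this small set with a true number. Compound 2 `COc1cccc(N2C(=O)COc3ccc(-c4cnc(OC)c(NS(=O)(=O)c5ccc(F)cc5)c4)cc32)c1` is reported at > 40000 nM as a limit of the assay and not a number. Compound 3 `COc1cccc(N2C(=O)COc3ccc(-c4cccc(NS(=O)(=O)c5ccc(F)cc5)c4)cc32)c1` likewise stands only at > 40000 nM as a limit and not a number. The set is thus marked by the limit of > 40000 nM in this assay, at which 2 of the 3 values shown sit, and compound 3 offers no firm value from which to measure a step.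

Compound 4 `O=C1COc2ccc(-c3cccc(NS(=O)(=O)c4ccc(F)cc4)c3)cc2N1c1ccc(Cl)cc1` has yet to be measured. Compared with compound 3 it carries 4-chlorophenyl in place of 3-methoxyphenyl on an amide-type nitrogen in a ring, and the counted difference is 4-chlorophenyl in place of 3-methoxyphenyl on an amide-type nitrogen in a ring with the rest of the structure unchanged. For the measured compounds named here, no measured pair in the set tests this exchange. In this assay the estimated step of an at least 1.3-fold lower number from compound 3 to compound 4 (0.12 log units; that floor lies within the scatter) is expected to stay within the usual scatter, with no firm direction. Going by the values given here, that expectation leans on compound 1 at 30100 nM as the only number available. Another result reported only as a limit would be no surprise. In this assay compound 4 is expected at about 30000 nM with 10000 nM to 60000 nM as the estimated range.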

Compound 4, half-maximal inhibitory concentration: 23900 nM
Estimate against measurement, compound 4: 1.3-fold (0.10 log units) above; measured number inside the range.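

Among the compounds shown here, at the amide-type nitrogen in a ring, the exchange of 3-methoxyphenyl for 4-chlorophenyl gives the first pair in this set that differs in one place, and in this assay it reads as an at least 1.6-fold lower number from compound 3 to compound 4 (0.22 log units; that floor lies within the scatter). Going by these compounds, that step is only a floor, and the true size of the change stays unknown because one end of the pair is a limit of the assay and not a number: the limit of > 40000 nM in this assay, at which 2 of the 4 values shown sit. Compound 4 does show that this nitrogen can carry an aryl group other than 3-methoxyphenyl and still return a true number on the shared core, although the floor alone establishes no real difference from compound 3.

The pair changes both the ring substituent and its place at once, which leaves the effect of the chlorine apart from that of its position unresolved. On these data alone, how a 4-aminophenyl group, a 4-carboxyphenyl group or a plain butyl chain on this nitrogen would read in this assay also remains open.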